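Cyclopentyl to cyclohexyl: working notes on the series

This account rests on a few compounds, and the source may have more. Where it says the series, first, only, none or still open, it means among the compounds named here.

compound 1 `O=C(O)[C@H]1CC[C@H](C(=O)N2CC[C@](c3ccc(C(OCc4ccccc4OC(F)(F)F)(C(F)(F)F)C(F)(F)F)cc3)(S(=O)(=O)c3ccc(F)cc3)C2)CC1`: 93%
compound 2 `O=C(O)[C@H]1CC[C@H](C(=O)N2CC[C@](c3ccc(C(OCC4CCC4)(C(F)(F)F)C(F)(F)F)cc3)(S(=O)(=O)c3ccc(F)cc3)C2)CC1`: 85%
compound 3 `O=C(O)[C@H]1CC[C@H](C(=O)N2CC[C@](c3ccc(C(OCC4CCCC4)(C(F)(F)F)C(F)(F)F)cc3)(S(=O)(=O)c3ccc(F)cc3)C2)CC1`: 73%

In an ADME assay on microsomes from liver (Homo sapiens) for metabolic stability, with a stated time of 10 min (a higher number here means that more of the compound is left, a lower number that less of the compound is left), compound 3 stands lowest of the three at 73%. Compound 4 `O=C(O)[C@H]1CC[C@H](C(=O)N2CC[C@](c3ccc(C(OCC4CCCCC4)(C(F)(F)F)C(F)(F)F)cc3)(S(=O)(=O)c3ccc(F)cc3)C2)CC1`, not yet measured, differs from it as follows: cyclohexyl in place of cyclopentyl on a saturated chain carbon bound to an oxygen on a saturated carbon. The closest measured change, cyclopentyl in place of cyclobutyl, gave a number 12 percentage points lower from compound 2 to compound 3 (beyond the scatter). Replacing 2-(trifluoromethoxy)phenyl gave a number 8 percentage points lower from compound 1 to compound 2 (within the scatter) with cyclobutyl and a number 20 percentage points lower from compound 1 to compound 3 (beyond the scatter) with cyclopentyl. Three compounds establish no firm trend, but a further modest drop in this assay is expected, similar in size to the step to compound 3. The expected step is a number 11 percentage points lower from compound 3 to compound 4 (beyond the scatter). Compound 4 is estimated at 62%, with an expected range of 45% to 77%.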

Compound 4, percent of the compound remaining: 92%
Compound 4: middle estimate off by 30 percentage points, on the low side; measured number outside the range, above it.
By their numbers in this assay, from the lowest: compound 3; then compounds 2, 4 and 1 (each within the scatter of the next).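

In this assay ring size on this carbon gives no steady fall: cyclohexyl brings a number 19 percentage points higher from compound 3 to compound 4 (beyond the scatter) and so reverses the drop seen with cyclopentyl. Cyclohexyl also shows a number 7 percentage points higher from compound 2 to compound 4 (within the scatter) with cyclobutyl as the group replaced and a number 1 percentage points lower from compound 1 to compound 4 (within the scatter) with 2-(trifluoromethoxy)phenyl as the group replaced, which leaves compound 3 as the single low number of the four. No measurement at hand explains this dip at cyclopentyl. Open, from the compounds shown here alone, is how a cycloheptyl ring or an open alkyl chain on this carbon would behave, and whether the dip recurs on another core.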